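Methyl to Isopropyl: Where Compound 4 Is Expected to Land

The source may report more compounds than this note shows. Statements on the series, on what has been measured and on what is new or still open speak of the compounds shown alone.

compound 1 `O=C(O)COc1ccc(NC(=O)COc2ccccc2)cc1F`: 29.8%
compound 2 `Cc1ccccc1OCC(=O)Nc1ccc(OCC(=O)O)c(F)c1`: 20.8%
compound 3 `Cc1cccc(OCC(=O)Nc2ccc(OCC(=O)O)c(F)c2)c1`: 45.4%

In a functional assay on CHO cells for agonist activity at Free fatty acid receptor 1 (Homo sapiens), read by FLIPR, tested at 100 nM (on this read-out higher numbers stand for a stronger effect at the one concentration tested and lower numbers for a weaker effect), compound 3 stands highest of the three measured numbers. Its nearest neighbour is compound 1, shown by a number 15.6 percentage points higher from compound 1 to compound 3 (beyond the scatter), and its furthest is compound 2, shown by a number 24.6 percentage points higher from compound 2 to compound 3 (beyond the scatter). Compound 4 `CC(C)c1cccc(OCC(=O)Nc2ccc(OCC(=O)O)c(F)c2)c1` differs from compound 3 in one place: isopropyl in place of methyl on an aromatic carbon. Among the compounds with values here, no measured step exchanges a methyl for an isopropyl, so the closest guides are a number 15.6 percentage points higher from compound 1 to compound 3 (beyond the scatter), which shows that a methyl at this place raises the read-out, and a number 9 percentage points lower from compound 1 to compound 2 (within the scatter), which lies within the scatter. Whether a larger group at the same place keeps that gain is not shown by these compounds. Compound 4 is therefore expected to give a step of about a number 4.6 percentage points higher from compound 3 to compound 4 (within the scatter). The estimate for compound 4 is 50%, with a range from 25% to 75%.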

Compound 4, a percentage reported as activity, at one concentration (the size of the read-out at that concentration, not a potency): 43.3%
Estimate against measurement, compound 4: 6.7 percentage points above; measured number inside the range.
By their numbers in this assay, from the lowest: compounds 2 and 1 (each within the scatter of the next); then compounds 4 and 3 (each within the scatter of the next).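

In this assay the meta place on the phenyl ring takes isopropyl as well as methyl, with a number 2.1 percentage points lower from compound 3 to compound 4 (within the scatter). The larger group also keeps the read-out clear of the unsubstituted compound, with a number 13.5 percentage points higher from compound 1 to compound 4 (beyond the scatter), so the rise seen with methyl at this place is not confined to methyl. Nothing available explains why the two groups read alike. From the compounds shown here alone, whether a longer chain, a tert-butyl group or an amine at this place would hold the read-out stays open. All four numbers show only a stronger or weaker effect at the one concentration tested.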